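Notes on a chloro-to-tert-butyl exchange in one series

A few compounds are considered here, and "the series" means these few. Any claim that something is new, unique, unknown or untested is made for them only; others in the source may bear on it.

Measured compounds:
compound 1 `O=C1NNC(=O)C2(CSC3=C2C(=O)c2ncccc2C3=O)N1` — 1580 nM; 1600 nM; 1600 nM (3 entries)
compound 2 `O=C1C2=C(C(=O)c3ncccc31)C1(CS2)NC(=O)N(c2ccc(Cl)cc2)C1=O` — 2 nM
compound 3 `Cc1ccc(N2NC(=O)NC3(CSC4=C3C(=O)c3ncccc3C4=O)C2=O)cc1` — 200 nM

In a functional assay on HT-29 cells (Homo sapiens) for antiproliferative activity, read by MTT assay, with a stated time of 96 h (a higher number here means a weaker inhibitor, a lower number a stronger inhibitor), compound 2 gives 2 nM, the lowest of the two single numbers on hand. The nearest is compound 3, which gives 200 nM, a gap far beyond the scatter. Compound 1 appears only as repeated entries (the several entries of compound 1 in this assay, 1580 nM; 1600 nM; 1600 nM (3 entries)), which sit close to one another and well above both of the others. No two of these compounds differ in a single place, so no measured step is available to calibrate the change below.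

Compound 4 `CC(C)(C)c1ccc(N2C(=O)NC3(CSC4=C3C(=O)c3ncccc3C4=O)C2=O)cc1` is the next candidate. It differs from compound 2 by tert-butyl in place of chloro on an aromatic carbon. With no measured step of this kind in this assay, the expectation rests on the low value of compound 2 alone; a move in either direction within the scatter, or a mild rise in number, seems the most plausible outcome, since the aryl substituent pattern in compound 3 is not comparable point for point.

Compound 4 is therefore expected at 5 nM, within a range of 1.5 nM to 25 nM. The step this implies, from compound 2 to compound 4, is estimated as a 2.5-fold higher number from compound 2 to compound 4 (0.40 log units; beyond the scatter).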

Compound 4, half-maximal inhibitory concentration: 150 nM
For compound 4 the middle estimate is 30-fold (1.48 log units) below the measured one, and the stated range ends below it.
By their numbers in this assay, from the lowest: compound 2; then compounds 4 and 3 (each within the scatter of the next).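

In this assay, for the compounds shown here, the exchange of chloro for tert-butyl on the aromatic carbon para to a large group gives a 75-fold higher number from compound 2 to compound 4 (1.88 log units; beyond the scatter), the first measured step that can be assigned to one place. The low number of compound 2 therefore does not carry over to every group at this position: with the rest of the structure unchanged, this single exchange is enough to produce a large change in the read-out, so the 4-chlorophenyl and 4-(tert-butyl)phenyl compounds cannot be treated as interchangeable. Nothing on hand gives a measured reason for this step, so the result stands as an observation on one pair of compounds.

Going by these compounds, with only chloro and tert-butyl compared at this place, one step defines no trend, and it remains open whether chloro is unusually favourable or tert-butyl is unusually unfavourable. Fluoro, methoxy or an amine at the same carbon on the same core would show where other groups fall relative to compound 2 and compound 4.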